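Trading a trifluoromethyl for hydrogen on the benzyl ring

The source may report more compounds than this note shows. Statements on the series, on what has been measured and on what is new or still open speak of the compounds shown alone.

Measured so far:
Compound 1, `C#CCNC1CCc2c(SCc3cccc(F)c3)cccc21`, gives 11600 nM.
Compound 2, `C#CCNC1CCc2c(SCc3ccc(C(F)(F)F)cc3)cccc21`, gives 930 nM.

Both compounds were tested in an ADME assay on isolated protein for inhibition of Amine oxidase [flavin-containing] B (Homo sapiens); a higher number here means a weaker inhibitor, a lower number a stronger inhibitor. Of the two numbers, compound 2 stands at the lower end, meaning it is the stronger inhibitor of the pair; compound 1 gives a number that is higher by a margin well beyond the usual scatter of this kind of measurement. The two compounds differ in what sits on the benzyl ring, so nothing more can be drawn from this pair alone.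

Compound 3, `C#CCNC1CCc2c(SCc3ccccc3)cccc21`, has not yet been measured. It differs from compound 2 in one place: hydrogen in place of trifluoromethyl on an aromatic carbon. Going by the values given here, there is no measured pair in this set that shows the effect of removing a group from that ring, so the size of this step is not known from the data.

The expectation is that compound 3 will give a higher number than compound 2, a step of a 4.3-fold higher number from compound 2 to compound 3 (0.63 log units; beyond the scatter), which would lie beyond the scatter. Compound 3 is therefore estimated at 4000 nM, with a range from 1000 nM to 15000 nM.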

Compound 3, half-maximal inhibitory concentration: "not active" (no number reported)
The entry for compound 3 holds no number; the estimate stays without a comparison.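

In this assay, going by these compounds alone, compound 3 is recorded as "not active" without a number, so no step from compound 2 to compound 3 can be read. Nothing shown here offers an explanation for this result. Going by these compounds, what stays open is how large the gap between compound 2 and compound 3 really is.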